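A few compounds are considered here, and "the series" means these few. Any claim that something is new, unique, unknown or untested is made for them only; others in the source may bear on it.

Working notes on the series. The shared core of compound 1 `O=C1O/C(=C\Cn2cc(-c3ccc(Br)cc3)nn2)C(OCc2ccccc2)=C1OCc1ccccc1` carries a 4-bromophenyl group on the five-membered aromatic ring with three nitrogens. In a functional assay on A549 cells (Homo sapiens) for antiproliferative activity, read by MTT assay, with a stated time of 72 h (a lower number here means a stronger inhibitor, a higher number a weaker inhibitor), compound 1 gives only a limit, recorded as > 100000 nM, so no number stands for it. Compound 2 `O=C1O/C(=C\Cn2cc(-c3cc(C(F)(F)F)cc(C(F)(F)F)c3)nn2)C(OCc2ccccc2)=C1OCc1ccccc1` carries a 3,5-bis(trifluoromethyl)phenyl group at the same place. In this assay compound 2 likewise gives only a limit, > 100000 nM. Among the compounds with values here, the single piece of evidence across the two measured compounds is the limit of > 100000 nM in this assay, at which 2 of the 2 values shown sit, so compound 1 stands at the limit and nothing ranks it against compound 2. Within the data shown here, no step between measured compounds can be read.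

Compound 3 `COc1ccccc1-c1cn(C/C=C2\OC(=O)C(OCc3ccccc3)=C2OCc2ccccc2)nn1` differs from compound 1 by 2-methoxyphenyl in place of 4-bromophenyl on an aromatic carbon. Since both measured aryl groups sit at the limit, the change of aryl group is not expected to move the number beyond the scatter, and the most likely outcome for compound 3 is again a limit rather than a value. Compound 3 is therefore estimated at 150000 nM, within 30000 nM to 600000 nM, an expected step that the limit leaves unreadable from compound 1 to compound 3.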

Compound 3, half-maximal inhibitory concentration: > 100000 nM
Compound 3 gave a limit, no number (the forecaster's own chance of this, stated with the estimate: 75%); the middle value does not contradict the limit.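

No step can be read from compound 1 to compound 3, as each gives only a limit and no number, and the one result they share is: the limit of > 100000 nM in this assay, at which 3 of the 3 values shown sit.

The compounds shown leave open whether any aryl group on the shared core gives a measurable value in this assay, and how such groups would rank.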